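The compounds below may be only part of what the source reports. "The series", "measured", "known", "first", "only" and "open" are said of these compounds alone.

Measured so far in a functional assay on FaDu cells (Homo sapiens) for antiproliferative activity, read by sulforhodamine B assay, with a stated time of 48 h; a lower number here means a stronger inhibitor, a higher number a weaker inhibitor:
Compound 1 `CCCCN(C)C(=O)CCCOc1cc(OC)c(OC)c2oc(-c3ccc(OC)cc3)c(O)c(=O)c12`: > 40000 nM
Compound 2 `COc1ccc(-c2oc3c(OC)c(OC)cc(OCCCC(=O)NCc4ccccn4)c3c(=O)c2O)cc1`: > 40000 nM

Both entries are limits of this assay, not numbers. Compound 2 therefore stands only at a limit, > 40000 nM. This is the limit of > 40000 nM in this assay, at which 2 of the 2 values shown sit.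

Compound 3 `COc1ccc(-c2oc3c(OC)c(OC)cc(OCCCC(=O)N4CCN(C)CC4)c3c(=O)c2O)cc1` carries 4-methylpiperazin-1-yl in place of ((pyridin-2-yl)methyl)amino on a carbonyl carbon.

One measured step changes the group at this same carbonyl carbon, a step that the two limits leave unreadable from compound 1 to compound 2, so no size can be carried over from it. Neither amide has yet given a number, and the new group offers no measured reason to expect a change. The expected a number no higher from compound 2 to compound 3 (the limit leaves the size open) is therefore none beyond the scatter, with no direction favoured. Compound 3 is estimated at 40000 nM, with an expected range of 15000 nM to 80000 nM.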

Compound 3, half-maximal inhibitory concentration: > 40000 nM
Compound 3: no number, only a limit; the forecaster's own chance of this, stated with the estimate: 75%; the middle value sits exactly at the limit.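

In this assay, compound 1, compound 2 and compound 3 all stand only at a limit, so no step among them can be read: the limit of > 40000 nM in this assay, at which 3 of the 3 values shown sit.

The compounds shown leave open whether any group on this carbonyl carbon would give a measurable number, and how these three groups compare.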